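Amide-aryl swap from compound 2 to compound 4

This account rests on a few compounds, and the source may have more. Where it says the series, first, only, none or still open, it means among the compounds named here.

Three compounds on the shared core have been run in an ADME assay on Vero cells (Chlorocebus sabaeus) for cytotoxicity, read by MTT assay; on this read-out lower numbers stand for higher toxicity in this test and higher numbers for lower toxicity in this test. Compound 1 `O=C(Nc1ccc(S(=O)(=O)N2CCCC2)cc1)c1ccc(C(F)(F)F)cc1` returns only the limit of > 300000 nM in this assay. Compound 2 `O=C(Nc1ccc(S(=O)(=O)N2CCCC2)cc1)c1ccc(F)cc1` likewise gives only the limit > 300000 nM. Compound 3 `Cc1nc(C(F)(F)F)ccc1C(=O)Nc1ccc(S(=O)(=O)N2CCCC2)cc1` also sits at the limit > 300000 nM. Hence the limit of > 300000 nM in this assay, at which 3 of the 3 values shown sit, is all the series shows so far, and the step of fluoro in place of trifluoromethyl on an aromatic carbon a step that the two limits leave unreadable from compound 1 to compound 2 cannot be sized. Compound 2 therefore stands at a limit only, with no number of its own in this assay.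

Compound 4 `Cc1cc(C(=O)Nc2ccc(S(=O)(=O)N3CCCC3)cc2)n(C)n1` differs from compound 2 by 1,3-dimethyl-1H-pyrazol-5-yl in place of 4-fluorophenyl on a carbonyl carbon. For the measured compounds named here, no measured step bears on this change, and the single step measured is itself unreadable. The expectation is that compound 4 also does not fall below the limit, so the step of a number no higher from compound 2 to compound 4 (the limit leaves the size open) is expected to stay within the scatter. Compound 4 is estimated at 300000 nM, within 100000 nM to 1000000 nM, and is most likely to be reported again only as a limit.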

Compound 4, half-maximal cytotoxic concentration: > 300000 nM
Compound 4: a limit, no number; the forecaster's own chance of this, stated with the estimate: 80%; the middle value sits exactly at the limit.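

In this assay compound 4 gives > 300000 nM, a limit and not a number. With compound 2 also at a limit, the step to compound 4 cannot be read. The compounds shown leave open whether any change on the shared core gives a readable number in this assay.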